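This account rests on a few compounds, and the source may have more. Where it says the series, first, only, none or still open, it means among the compounds named here.

Measured compounds, with their values in a functional assay on cells (Cancer cell lines, Homo sapiens) for cytotoxicity, read by sulforhodamine B assay, with a stated time of 48 h; a higher number here means a weaker inhibitor of growth, a lower number a stronger inhibitor of growth:

- compound 1, `COc1ccc(C2=NN(C3=NC(=O)/C(=C4\C(=O)Nc5ccc(Br)cc54)S3)C(c3ccc(OC)cc3)C2)cc1` — compound 1 gives 405 nM
- compound 2, `COc1ccc(C2=NN(C3=NC(=O)/C(=C4\C(=O)Nc5ccc(Cl)cc54)S3)C(c3ccc(OC)cc3)C2)cc1` — compound 2 gives 420 nM
- compound 3, `CN(C)c1ccc(C2CC(c3ccccc3)=NN2C2=NC(=O)/C(=C3\C(=O)Nc4ccc(Br)cc43)S2)cc1` — compound 3 gives 450 nM

Among the measured compounds shown here, the three measured values sit close together, and none of the gaps between them is printed as beyond the usual scatter, so no compound can be called stronger or weaker than another on these numbers alone.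

Compound 1 and compound 2 share a core and differ in one place: chloro in place of bromo on an aromatic carbon. This change gave a 1.0-fold higher number from compound 1 to compound 2 (0.02 log units; within the scatter).

Compound 3 carries a different core; the difference between the core of compound 3 and the core of compound 1 is not broken down here.

The unmeasured compound 4, `CN(C)c1ccc(C2CC(c3ccccc3)=NN2C2=NC(=O)/C(=C3\C(=O)Nc4ccc(Cl)cc43)S2)cc1`, relates to compound 3 exactly as compound 2 relates to compound 1: chloro in place of bromo on an aromatic carbon. The place description is the same word for word in both pairs, so this is the same change made on a second core.

On that basis the step from compound 3 to compound 4 in this assay is expected to be about as small as the step from compound 1 to compound 2, estimated at a 1.0-fold higher number from compound 3 to compound 4 (0.01 log units; within the scatter), because the earlier change gave a 1.0-fold higher number from compound 1 to compound 2 (0.02 log units; within the scatter) and compound 3 starts from 450 nM. Compound 4 is therefore expected to give about 460 nM, with a plausible range from 250 nM to 850 nM.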

Compound 4, concentration for total growth inhibition: 430 nM
Compound 4: the middle estimate sits 1.1-fold (0.03 log units) above what was measured; low and high end bracket the measured number.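

In this assay, among the compounds shown here, chloro in place of bromo on an aromatic carbon gives a 1.0-fold lower number from compound 3 to compound 4 (0.02 log units; within the scatter), so on the core of compound 3, as on the core of compound 1, the exchange produces no step that can be told apart from repeated measurement. Set side by side, the two steps agree, and in this read-out the exchange carries from one core to the other as a change without a measurable consequence: the same change on two cores in this assay, a 1.0-fold higher number (0.02 log units; within the scatter) from compound 1 to compound 2 and a 1.0-fold lower number (0.02 log units; within the scatter) from compound 3 to compound 4, 1.1-fold (0.04 log units) apart, within the scatter of two such steps. For the compounds shown here, this agreement rests on two cores and on one halogen exchange, and two steps that both lie within the scatter show only that neither core responds to it, not that a change with a larger step would carry across these cores equally well, nor why the exchange makes so little difference.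

The compounds shown hold only bromo or chloro at this place on the fused system, so it remains open whether fluoro, plain hydrogen, a nitrile, an amine or a carboxylic acid there would leave the read-out as flat. Also open, on these data alone, is whether any such group would give steps of a readable size, which could then be compared properly between the core of compound 1 and the core of compound 3.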